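From nitro to methyl on a shared core

The source may hold more compounds than are shown below. What is called first, only, known or untested is meant among the compounds shown, and "the series" means these compounds.

Measured so far in an ADME assay on Vero cells (Chlorocebus sabaeus) for cytotoxicity, read by MTT assay, with a stated time of 72 h; on this read-out higher numbers stand for weaker inhibition and lower numbers for stronger inhibition:
Compound 1 `CNc1c(NCc2ccc(OC)cc2)ncnc1-c1ccco1`: "not determined" (no result reported)
Compound 2 `COc1ccc(CNc2nc([N+](=O)[O-])nc(-c3ccco3)c2NC=O)cc1`: > 40 ug/mL

In this assay compound 2 gives > 40 ug/mL, which is a limit of the assay and not a number. Compound 2 therefore stands without a single figure, and compound 1 supplies no number to set beside it.

Compound 3 `COc1ccc(CNc2nc(C)nc(-c3ccco3)c2NC=O)cc1` has methyl in place of nitro on an aromatic carbon, between two ring nitrogen atoms and para to a formylamino group (methyl in place of nitro on an aromatic carbon). Among the measured compounds shown here, no measured pair shows the effect of such a change, so no step beyond the scatter is expected in this assay, and no direction is favoured. The estimated change a step that the limit leaves unreadable from compound 2 to compound 3 is correspondingly small. This expectation rests only on compound 2, whose > 40 ug/mL is a limit. For compound 3 the expected value is 45 ug/mL, with an estimated range from 18 ug/mL to 100 ug/mL.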

Compound 3, half-maximal inhibitory concentration: > 40 ug/mL
Compound 3: no number, only a limit (the forecaster's own chance of this, stated with the estimate: 60%); the middle value does not contradict the limit.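

Compound 3 gives > 40 ug/mL as a limit of the assay and not a number. Among the compounds shown here, no step from compound 2 to compound 3 can be read, because compound 2 stands at a limit too: the limit of > 40 ug/mL in this assay, at which 2 of the 3 values shown sit.

The compounds shown leave open how far either compound lies beyond that limit, and whether methyl in place of nitro changes the value at all.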